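Methyl for methoxy on the benzoyl ring of compound 2

The compounds below may be only part of what the source reports. "The series", "measured", "known", "first", "only" and "open" are said of these compounds alone.

Two compounds have a number in a functional assay on KB cells (Homo sapiens) for cytotoxicity, read by MTT assay, with a stated time of 72 h; a higher number here means a weaker inhibitor, a lower number a stronger inhibitor. Compound 1 `COc1cc2ncnc(NNC(=S)NC(=O)c3ccc(F)cc3)c2cc1OC` gives 4530 nM in this assay. Compound 2 `COc1ccccc1C(=O)NC(=S)NNc1ncnc2ccccc12` reaches only the limit of this assay, > 50000 nM, so no number is known for it. Among the measured compounds shown here, compound 1 and compound 2 differ in more than one place and no single step between them is counted; their two values show only that compound 1 gives a number and compound 2 does not. Compound 2 sits at the limit (the limit of > 50000 nM in this assay, at which 1 of the 2 values shown sits), the weaker end of what is recorded.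

Compound 3 `Cc1ccccc1C(=O)NC(=S)NNc1ncnc2ccccc12` follows from compound 2 by the change (methyl in place of methoxy on an aromatic carbon), methyl in place of methoxy on an aromatic carbon. The rest of the molecule, the linking chain and the shared core, is kept. With compound 2 at the limit, a step of this size leaves no measured anchor; the expectation for compound 3 is no shift beyond the scatter, with a step from compound 2 to compound 3 of a number no higher from compound 2 to compound 3 (the limit leaves the size open). Compound 3 is expected to give about 50000 nM in this assay, within 15000 nM to 150000 nM, most likely again reported only as a limit.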

Compound 3, half-maximal inhibitory concentration: 2770 nM
Compound 3: middle estimate off by 18-fold (1.26 log units), on the high side; measured number outside the range, below it.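

In this assay, methyl in place of methoxy on an aromatic carbon, ortho to a large group, gives an at least 18-fold lower number from compound 2 to compound 3 (1.25 log units; beyond the scatter), so the group held at this place on the benzoyl ring matters for the read-out in this series. Among the compounds shown here, the earlier pair, compound 1 and compound 2, differed in more than one place and could not isolate any single position; this is the first step that changes one place only, and it turns a limit into a measured number while the linking chain and the shared core stay as they were. The step has a lower bound and no exact size, because one end of it is a limit and not a number: the limit of > 50000 nM in this assay, at which 1 of the 3 values shown sits.

Going by these compounds, whether an ethyl group, a chlorine atom or a plain hydrogen on this same carbon would match the value of compound 3 remains open, as does whether methyl on another carbon of the ring would give a step of this kind. Also open is whether the same change would carry over to the core of compound 1, and the compounds shown give no reason for the size of the step.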